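The source may report more compounds than this note shows. Statements on the series, on what has been measured and on what is new or still open speak of the compounds shown alone.

Compound 1, `S=c1oc(-c2ccc3c(c2)OCCO3)nn1CNC1CCCCC1`, carries a cyclohexyl group on its amine nitrogen. In a functional assay, with a stated time of 6 min (on this read-out higher numbers stand for weaker inhibition and lower numbers for stronger inhibition), compound 1 gives 18400 nM, the highest number among the three compounds measured; the nearest to it is compound 3 and the furthest is compound 2. Compound 2, `Fc1cc(NCn2nc(-c3ccc4c(c3)OCCO4)oc2=S)cc(F)c1F`, gives 2920 nM in this assay, and compound 3, `S=c1oc(-c2ccc3c(c2)OCCO3)nn1CNc1ccccc1Cl`, gives 7230 nM.

The step under consideration leads from compound 1 to compound 4, `S=c1oc(-c2ccc3c(c2)OCCO3)nn1CNc1cc(Cl)ccc1Cl`. The change is 2,5-dichlorophenyl in place of cyclohexyl on an amine nitrogen.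

Among the measured compounds shown here, two measured steps bear on this change, since each also replaces the cyclohexyl on the amine nitrogen with a substituted phenyl ring. There was a 6.3-fold lower number from compound 1 to compound 2 (0.80 log units; beyond the scatter), and there was a 2.5-fold lower number from compound 1 to compound 3 (0.41 log units; beyond the scatter). Between the two aryl compounds themselves there was a 2.5-fold higher number from compound 2 to compound 3 (0.39 log units; beyond the scatter). Both aryl replacements therefore lowered the number beyond the scatter, though by different modest amounts, and the 2,5-dichlorophenyl of compound 4 is expected to behave in the same direction. On this basis the step in this assay from compound 1 to compound 4 is expected to be a modest lowering, a 3.7-fold lower number from compound 1 to compound 4 (0.57 log units; beyond the scatter), somewhere between the steps seen for compound 2 and compound 3. Compound 4 is accordingly estimated at 5000 nM in this assay, within a range from 2000 nM to 12000 nM.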

Compound 4, half-maximal inhibitory concentration: 5420 nM
Estimate against measurement, compound 4: 1.1-fold (0.04 log units) below; low and high end bracket the measured number.
By their numbers in this assay, from the lowest: compounds 2, 4 and 3 (each within the scatter of the next, the first and the last beyond it); then compound 1.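

In this assay the 2,5-dichlorophenyl group gives a 3.4-fold lower number from compound 1 to compound 4 (0.53 log units; beyond the scatter) and thus adds a third substituted phenyl ring on the amine nitrogen that stands clear of the cyclohexyl compound, with none of the three going against this direction. The second chlorine adds nothing that can be read, since the chloro in place of hydrogen on an aromatic carbon gives a 1.3-fold lower number from compound 3 to compound 4 (0.13 log units; within the scatter) and stays within the scatter, and the exchange of the halogen pattern gives a 1.9-fold higher number from compound 2 to compound 4 (0.27 log units; within the scatter) and also stays within it. Compound 4 therefore cannot be separated from either neighbour, even though those two are set apart by a 2.5-fold higher number from compound 2 to compound 3 (0.39 log units; beyond the scatter) and no information is available to account for any of these differences.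

All the aryl groups shown carry only chlorine or fluorine, so it remains open whether an unsubstituted phenyl, a methoxyphenyl or a pyridyl ring on the same nitrogen would keep the number on this side of compound 1. Cyclohexyl is also the only saturated group shown, which leaves open how a smaller ring such as cyclopentyl, or an open chain such as n-butyl, would compare with it.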